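The compounds below may be only part of what the source reports. "The series", "measured", "known", "first", "only" and "open" are said of these compounds alone.

Compound 1 `Cc1nc(S(C)(=O)=O)ccc1Oc1ncnc(OC2CCN(C(=O)OC(C)C)CC2)c1F`: 77%
Compound 2 `Cc1nc(S(C)(=O)=O)ccc1Oc1ncnc(OC2CCN(C(=O)O[C@H](C)CF)CC2)c1F`: 79%
Compound 3 `Cc1nc(S(C)(=O)=O)ccc1Oc1ncnc(OC2CCN(C(=O)OC3(C(F)(F)F)CCC3)CC2)c1F`: 82%

The three compounds share one core and differ only in the group on an oxygen next to a carbonyl group. In a functional assay on isolated protein for inhibition of Glucose-dependent insulinotropic receptor (Rattus norvegicus), read by HTRF and cAMP accumulation (on this read-out lower numbers stand for smaller maximal responses and higher numbers for larger maximal responses), compound 3 gives 82%, the number at the upper end of the set, yet the steps of a number 5 percentage points higher from compound 1 to compound 3 (within the scatter) and a number 3 percentage points higher from compound 2 to compound 3 (within the scatter) both lie within the scatter, as does a number 2 percentage points higher from compound 1 to compound 2 (within the scatter), so the three compounds cannot be told apart on this read-out.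

Compound 4 `Cc1nc(S(C)(=O)=O)ccc1Oc1ncnc(OC2CCN(C(=O)SC(C)(C)C)CC2)c1F` has not yet been measured. a group of 5 heavy atoms (4 carbon, 1 sulfur; no ring) in place of a group of 9 heavy atoms (5 carbon, 1 oxygen, 3 fluorine; one four-membered non-aromatic ring of carbon only), on a carbonyl carbon The (tert-butyl)sulfanyl sits on a carbonyl carbon whose other neighbours are an amide-type nitrogen in a ring. The measured steps that bear on this change are a number 5 percentage points higher from compound 1 to compound 3 (within the scatter), a number 3 percentage points higher from compound 2 to compound 3 (within the scatter) and a number 2 percentage points higher from compound 1 to compound 2 (within the scatter), each altering the group at that carbonyl and each staying within the scatter. Compound 4 is therefore expected to show no step beyond the scatter, a number 4 percentage points lower from compound 3 to compound 4 (within the scatter). For compound 4 the estimate in this assay is 78%, with a range from 68% to 88%.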

Compound 4, largest response reached (reported as efficacy), in percent of the reference or control that the assay uses: 76%
Beside the measured number, compound 4's estimate is 2 percentage points above it, and the stated range covers the measured number.
By their numbers in this assay, from the lowest: compounds 4, 1, 2 and 3 (each within the scatter of the next).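

Compound 4 shows that in this assay this carbonyl carbon also carries (tert-butyl)sulfanyl with no step beyond the scatter: a number 6 percentage points lower from compound 3 to compound 4 (within the scatter), a number 3 percentage points lower from compound 2 to compound 4 (within the scatter) and a number 1 percentage points lower from compound 1 to compound 4 (within the scatter). The earlier compounds shown here varied only the group on an oxygen next to a carbonyl group, whereas here sulfur takes the place of that oxygen, and the four compounds still cannot be told apart on this read-out. Nothing shown here offers an explanation for this result.

The compounds shown leave open whether another kind of group on this carbonyl carbon, such as an amine or a longer chain joined through sulfur, would give a step beyond the scatter. They also leave open how changes elsewhere on the shared core would read, since it stays the same in all four compounds.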